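Halogenated benzyl exchange on two hydroxamate cores

The source may hold more compounds than are shown below. What is called first, only, known or untested is meant among the compounds shown, and "the series" means these compounds.

Compound 1 `O=C(/C=C/c1ccc(OCc2nc(C3CCN(Cc4ccc(F)cc4)CC3)no2)cc1)NO` and compound 3 `CN(Cc1nc(C2CCN(Cc3ccc(F)cc3)CC2)no1)c1ncc(C(=O)NO)cn1` are built on different cores; the difference between the two cores is not broken down here. In an assay on isolated protein for inhibition of protein deacetylase HDAC6 (Homo sapiens), read by fluorescence, with a stated time of 1 h, tested at 100 nM (on this read-out higher numbers stand for more inhibition at the one concentration tested (going by the name of the read-out) and lower numbers for less inhibition), compound 1 gives 75%. Compound 2 `O=C(/C=C/c1ccc(OCc2nc(C3CCN(Cc4ccccc4Cl)CC3)no2)cc1)NO` differs from compound 1 in one place, (2-chlorophenyl in place of 4-fluorophenyl on a saturated chain carbon bound to an amine nitrogen in a ring). In this assay, for the measured compounds named here, compound 2 gives 59%, and the step of a number 16 percentage points lower from compound 1 to compound 2 (beyond the scatter) is the only measured instance of this change in the set. In this assay, going by the values given here, compound 3 gives 65%; this value lies within the scatter of the value of compound 2 and also within the scatter of the value of compound 1, so no order among compound 1, compound 2 and compound 3 beyond the one measured step can be stated.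

Compound 4 `CN(Cc1nc(C2CCN(Cc3ccccc3Cl)CC2)no1)c1ncc(C(=O)NO)cn1` has not yet been measured. It differs from compound 3 by 2-chlorophenyl in place of 4-fluorophenyl on a saturated chain carbon bound to an amine nitrogen in a ring, the same change as from compound 1 to compound 2, at the same place. The step to compound 4 is expected to be of the same size and direction, estimated as a number 16 percentage points lower from compound 3 to compound 4 (beyond the scatter), because a number 16 percentage points lower from compound 1 to compound 2 (beyond the scatter) was observed for the same change on the other core. Compound 4 is accordingly expected to give about 49% in this assay. The expected range runs from 35% to 62%; it is kept wide, as the change has been measured on one core only and the two cores are otherwise not compared here.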

Compound 4, a percentage reported as inhibition, at one concentration (the size of the read-out at that concentration, not a potency): 55%
Compound 4: the middle estimate sits 6 percentage points below what was measured; measured number inside the range.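

In this assay, the exchange of 4-fluorobenzyl for 2-chlorobenzyl on the core of compound 3 gives a number 10 percentage points lower from compound 3 to compound 4 (within the scatter), and the comparison with the other core shows no difference between the two steps that exceeds the scatter: the same change on two cores in this assay, a number 16 percentage points lower (beyond the scatter) from compound 1 to compound 2 and a number 10 percentage points lower (within the scatter) from compound 3 to compound 4, 6 percentage points apart, within the scatter of two such steps

The two measured steps are therefore compatible with a single effect of similar size that carries from one core to the other. They do not establish this, as the step on the core of compound 3 cannot on its own be separated from the scatter, and a single pair on each core gives no basis for a rule across the series.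

The change replaces 4-fluorophenyl with 2-chlorophenyl in one step, so the compounds shown leave open how much of the difference on the core of compound 1 goes with the identity of the halogen and how much with its place on the ring. Also open, going by these compounds, is how either core would respond to an unsubstituted phenyl, or to a phenyl carrying a methoxy group, on the same saturated chain carbon bound to an amine nitrogen in a ring.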